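Ring swap from compound 2 to compound 3

A few compounds are considered here, and "the series" means these few. Any claim that something is new, unique, unknown or untested is made for them only; others in the source may bear on it.

Measured so far in a functional assay on HCT-116 cells (Homo sapiens) for antiproliferative activity, read by MTT assay, with a stated time of 72 h; on this read-out higher numbers stand for weaker inhibition and lower numbers for stronger inhibition
- compound 1 `O=C(CCc1cccc2c1B(O)OC2)Nc1ccccc1` gives 350 nM
- compound 2 `CSc1cccc(-c2cccc(NC(=O)CCc3cccc4c3B(O)OC4)c2)c1` gives 110 nM

Of these two, compound 2 has the lowest number (110 nM) in this assay and is the stronger inhibitor, with the gap lying beyond the scatter. Among the measured compounds shown here, the one measured step bearing on the next change is a 3.2-fold lower number from compound 1 to compound 2 (0.50 log units; beyond the scatter), which placed 3-(methylsulfanyl)phenyl in place of hydrogen on an aromatic carbon. That step is modest.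

Next in the series is compound 3 `O=C(CCc1cccc2c1B(O)OC2)Nc1cccc(-c2ccc(C(F)(F)F)cc2)c1`, which has 4-(trifluoromethyl)phenyl in place of 3-(methylsulfanyl)phenyl on an aromatic carbon. The core and the amide stay as they are, and an outer phenyl ring is still present. For the measured compounds named here, no measured step exchanges one such ring for another, so the data give no direction for this swap. With only the modest step of compound 1 to compound 2 (a 3.2-fold lower number from compound 1 to compound 2 (0.50 log units; beyond the scatter)) as a guide, a smaller shift seems likely. The expected outcome is a 1.1-fold higher number from compound 2 to compound 3 (0.04 log units; within the scatter) in this assay with no change beyond the scatter. Compound 3 is estimated at 120 nM (expected range 45 nM to 320 nM) .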

Compound 3, half-maximal inhibitory concentration: 550 nM
Compound 3: the middle estimate sits 4.6-fold (0.66 log units) below what was measured; the whole stated range lies below it.
By their numbers in this assay, from the lowest: compound 2; then compounds 1 and 3 (each within the scatter of the next).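

In this assay, an outer ring at this position does not by itself carry the gain: a 1.6-fold higher number from compound 1 to compound 3 (0.20 log units; within the scatter), which puts compound 3 within the scatter of compound 1, the compound with hydrogen on this aromatic carbon. Among the compounds shown here, the result also gives the first measured exchange of one outer ring for another here, and a 5.0-fold higher number from compound 2 to compound 3 (0.70 log units; beyond the scatter) shows that this position responds to what the ring carries, so the earlier 3.2-fold lower number from compound 1 to compound 2 (0.50 log units; beyond the scatter) belongs to 3-(methylsulfanyl)phenyl in this pair of substituted compounds and not to any added phenyl ring. No measurement on hand accounts for the difference between these two rings.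

The compounds shown do not separate the identity of the group on the outer ring from its place on that ring: 3-(methylsulfanyl)phenyl and 4-(trifluoromethyl)phenyl differ in both. Also open, going by these compounds, is whether an outer ring bearing an amine or a carboxylic acid would stay with compound 2 at 110 nM or fall back within the scatter of compound 1.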